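The source may hold more compounds than are shown below. What is called first, only, known or untested is meant among the compounds shown, and "the series" means these compounds.

Of the compounds shown here, three of a shared core have been tested, and a fourth awaits testing. Compound 1 `C#CCSc1nnc(CCC)n1N1C(=O)c2ccccc2C1=O` carries a propargylsulfanyl group and a propyl chain; compound 2 `CCCc1nnc(SCc2ccccc2Cl)n1N1C(=O)c2ccccc2C1=O` has a (2-chlorobenzyl)sulfanyl group in place of the propargylsulfanyl group; compound 3 `COc1cc(-c2nnc(SCc3ccccc3Cl)n2N2C(=O)c3ccccc3C2=O)cc(OC)c1OC` keeps that (2-chlorobenzyl)sulfanyl group but carries a 3,4,5-trimethoxyphenyl ring instead of the propyl chain. Compound 4 `C#CCSc1nnc(-c2cc(OC)c(OC)c(OC)c2)n1N1C(=O)c2ccccc2C1=O` is still to be measured.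

In a functional assay on A549 cells (Homo sapiens) for cytotoxicity, read by MTT assay, with a stated time of 48 h (a lower number here means a stronger inhibitor, a higher number a weaker inhibitor), compound 1 gives > 200000 nM, which is a limit of the assay rather than a number. Compound 2 likewise gives > 200000 nM, again a limit. Compound 3 gives > 200000 nM, also a limit. Because all three sit at the limit of > 200000 nM in this assay, at which 3 of the 3 values shown sit, neither step among them can be read: the change ethynyl in place of 2-chlorophenyl on a saturated chain carbon bound to a sulfur gives a step that the two limits leave unreadable from compound 2 to compound 1, and the change of core 3,4,5-trimethoxyphenyl in place of propyl on an aromatic carbon gives a step that the two limits leave unreadable from compound 2 to compound 3.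

Compound 4 differs from compound 3 by ethynyl in place of 2-chlorophenyl on a saturated chain carbon bound to a sulfur, the same change that separates compound 2 from compound 1, made at a place described in the same words. Since that earlier step left both compounds at the limit, the step from compound 3 to compound 4 is expected to be a step that the limit leaves unreadable from compound 3 to compound 4, resting on compound 3 at > 200000 nM and on the earlier pair. Compound 4 is therefore estimated at 250000 nM, most likely reported again as a limit, with the plausible range running from 120000 nM to 600000 nM.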

Compound 4, half-maximal inhibitory concentration: > 200000 nM
Compound 4: a limit, no number (the forecaster's own chance of this, stated with the estimate: 85%); the middle value is on the limit's open side.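

In this assay compound 4 gives > 200000 nM, which is a limit and not a number. No size can be read for the step between compound 3 and compound 4, because neither compound has a numerical value: the limit of > 200000 nM in this assay, at which 4 of the 4 values shown sit.

The compounds shown leave open whether any change to the shared core would give a value in this assay that can be read as a number.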